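Cyanoguanidine chain length and methylation on a shared core

The source may report more compounds than this note shows. Statements on the series, on what has been measured and on what is new or still open speak of the compounds shown alone.

Compound 1 `N#CNC(=N)NCCCCCn1nc(-c2ccccc2)ccc1=O` in a functional assay on the whole organism (stomach) with Rattus norvegicus as the target (a lower number here means that less compound is needed, a higher number that more compound is needed for the effect), gives > 100 mg/kg, a limit of the assay. Compound 2 `C/N=C(/NC#N)NCCCCCCn1nc(-c2ccccc2)ccc1=O` in this assay gives > 100 mg/kg, also a limit. Compound 3 `CC/N=C(/NC#N)NCCCCCCn1nc(-c2ccccc2)ccc1=O` in this assay gives > 100 mg/kg, again a limit.

Compound 1 therefore stands only at a limit in this assay, and the other two values shown are limits as well, as the limit of > 100 mg/kg in this assay, at which 3 of the 3 values shown sit, records. Compound 4 `C/N=C(/NC#N)N(C)CCCCn1nc(-c2ccccc2)ccc1=O` differs from compound 1 in this way: a group of 8 heavy atoms (4 carbon, 4 nitrogen; no ring) in place of a group of 7 heavy atoms (3 carbon, 4 nitrogen; no ring), on a saturated chain carbon, four bonds along the chain from an aromatic nitrogen. For the measured compounds named here, the measured steps that touch the same part of the molecule are a step that the two limits leave unreadable from compound 1 to compound 2 and a step that the two limits leave unreadable from compound 1 to compound 3, and between those two compounds a step that the two limits leave unreadable from compound 2 to compound 3; none of them yields a readable size, so no measured step gives a direction for the change to compound 4, and the shift from five bonds to four bonds along the chain has no measured counterpart at all. With every value in this assay sitting at the limit, compound 4 is expected to stay near that limit too, so that a step that the limit leaves unreadable from compound 1 to compound 4 is expected to be no readable step. Compound 4 is estimated at 150 mg/kg in this assay, within 40 mg/kg to 600 mg/kg, with a high chance that only a limit is reported.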

Compound 4, dose for half-maximal effect: > 100 mg/kg
Compound 4: no number, only a limit; the forecaster's own chance of this, stated with the estimate: 75%; the middle value does not contradict the limit.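

No new step can be read: compound 4, like compound 1, stands only at a limit in this assay, and the record holds nothing but that limit: the limit of > 100 mg/kg in this assay, at which 4 of the 4 values shown sit. The compounds shown leave open whether chain length or methylation changes the dose needed for the effect in this assay; none of them gives a number.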